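Swapping the Aryl Group on a Triazole Series

The compounds below may be only part of what the source reports. "The series", "measured", "known", "first", "only" and "open" are said of these compounds alone.

Measured in a functional assay on PANC-1 cells (Homo sapiens) for inhibition, read by MTT assay, with a stated time of 24 h; on this read-out lower numbers stand for stronger inhibition and higher numbers for weaker inhibition:
- compound 1 `CC1(C)[C@H]2CC[C@]1(C)N(Cc1cn(-c3ccccc3)nn1)C(=O)C2`: 160 nM
- compound 2 `Cc1ccc(-n2cc(CN3C(=O)C[C@@H]4CC[C@@]3(C)C4(C)C)nn2)cc1`: 270 nM

Among the compounds with values here, compound 2 stands level with compound 1, the only other compound measured, because a 1.7-fold higher number from compound 1 to compound 2 (0.23 log units; within the scatter) does not separate them. The next compound, compound 3 `CC1(C)[C@H]2CC[C@]1(C)N(Cc1cn(-c3ccccc3O)nn1)C(=O)C2`, keeps the shared core but carries a different group on an aromatic nitrogen: 2-hydroxyphenyl in place of 4-methylphenyl on an aromatic nitrogen. Within the data shown here, the only measured step that bears on this change is the one between compound 1 and compound 2, a 1.7-fold higher number from compound 1 to compound 2 (0.23 log units; within the scatter), where a methyl replaces a hydrogen on an aromatic carbon. Among the measured compounds shown here, no measured compound carries a 2-hydroxyphenyl group, and the data offer no direct guide to it. A step beyond the scatter is therefore not expected in either direction, although the range must stay wide. The expected change is a 1.2-fold lower number from compound 2 to compound 3 (0.09 log units; within the scatter). The estimate for compound 3 is 220 nM, with an expected range from 70 nM to 700 nM.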

Compound 3, half-maximal inhibitory concentration: 230 nM
Estimate against measurement, compound 3: 1.0-fold (0.02 log units) below, within the range that was stated.
By their numbers in this assay, from the lowest: compounds 1, 3 and 2 (each within the scatter of the next).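

Trading 4-methylphenyl for 2-hydroxyphenyl on the aromatic nitrogen is a larger change than the earlier methyl step, since it brings in a hydrogen-bond donor and a hydrogen-bond acceptor where there were none, yet in this assay it gives a 1.2-fold lower number from compound 2 to compound 3 (0.07 log units; within the scatter) and does not separate the two compounds. The hydroxy group taken alone gives the same picture, with a 1.4-fold higher number from compound 1 to compound 3 (0.16 log units; within the scatter) and so, across these three compounds, neither the methyl nor the hydroxy group moves the number beyond the scatter. No measurement is available to explain why these compounds stand level.

Still open, as far as these compounds go, is whether an amine or a carboxylic acid on this aromatic ring would give a number beyond the scatter. A longer chain, such as propyl, in place of the methyl also remains untested among the compounds shown.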